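This account rests on a few compounds, and the source may have more. Where it says the series, first, only, none or still open, it means among the compounds named here.

Measured so far:
compound 1, `Cn1nnnc1SCC(=O)N/N=C/c1ccc([N+](=O)[O-])cc1` — 9300000 nM
compound 2, `Cn1nnnc1SCC(=O)N/N=C/c1ccc(F)cc1` — 10000000 nM

In an ADME assay on NIH3T3 cells (Mus musculus) for cytotoxicity, read by XTT assay, with a stated time of 24 h (on this read-out lower numbers stand for stronger inhibition and higher numbers for weaker inhibition), compound 1 gives the lowest of the two numbers; its nearest neighbour is compound 2, and the step of a 1.1-fold higher number from compound 1 to compound 2 (0.03 log units; within the scatter) lies within the scatter. Compound 3, `COc1ccc(/C=N/NC(=O)CSc2nnnn2C)cc1`, differs from compound 1 by methoxy in place of nitro on an aromatic carbon. Among the compounds with values here, the only step that bears on this change is the fluoro-for-nitro exchange, which moved the number hardly at all, so another change on the same aromatic carbon is expected to stay within the scatter. For compound 3 the expected step is a 1.0-fold higher number from compound 1 to compound 3 (0.01 log units; within the scatter), giving an estimate of 9500000 nM with a range from 4500000 nM to 20000000 nM.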

Compound 3, half-maximal inhibitory concentration: > 10000000 nM
Compound 3: only a limit was reported (the forecaster's own chance of this, stated with the estimate: 30%); at least 1.0-fold (0.02 log units) between middle value and limit.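

In this assay compound 3 gives > 10000000 nM as a limit and not a number. Methoxy thus joins fluoro as a second replacement for nitro on this aromatic carbon, with an at least 1.0-fold higher number from compound 1 to compound 3 (0.03 log units; that floor lies within the scatter) as its step, while the step of a number no lower from compound 2 to compound 3 (the limit leaves the size open) cannot be read. What this change shows at this position is bounded by that limit: the limit of > 10000000 nM in this assay, at which 1 of the 3 values shown sits. The compounds shown leave open how far the methoxy step truly reaches, and whether an amine or a carboxylic acid on this aromatic carbon would move the number beyond the scatter.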